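Amino in Place of Hydroxyethyl at the Solubility Floor

This account rests on a few compounds, and the source may have more. Where it says the series, first, only, none or still open, it means among the compounds named here.

Compound 1, `OCCCNc1nnc(-c2ccc(F)c(F)c2Nc2ccc(I)cc2F)o1`, gives < 3 ug/mL in a physicochemical assay for solubility, read by HPLC, in phosphate buffer, at pH 6.5 (a higher number here means a more soluble compound, a lower number a less soluble compound), which is a limit of the assay.
Compound 2, `OCCCCNc1nnc(-c2ccc(F)c(F)c2Nc2ccc(I)cc2F)o1`, gives < 3 ug/mL, a limit of the assay.
Compound 3, `COCCCNc1nnc(-c2ccc(F)c(F)c2Nc2ccc(I)cc2F)o1`, gives < 3 ug/mL, a limit of the assay.

Compound 2 stands at the limit of < 3 ug/mL in this assay, at which 3 of the 3 values shown sit. It is not a number but a floor, and the two further values around it are likewise only limits. The three steps among the measured compounds, a step that the two limits leave unreadable from compound 1 to compound 2, a step that the two limits leave unreadable from compound 1 to compound 3 and a step that the two limits leave unreadable from compound 2 to compound 3, are all left unreadable by those limits, and none of them has a size that could be carried forward.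

Compound 4, `NCCNc1nnc(-c2ccc(F)c(F)c2Nc2ccc(I)cc2F)o1`, differs from compound 2 by amino in place of 2-hydroxyethyl on a saturated chain carbon, two bonds along the chain from a nitrogen on an aromatic ring. Since every measured step is unreadable, as a step that the two limits leave unreadable from compound 1 to compound 2 and a step that the two limits leave unreadable from compound 2 to compound 3 show, the data give no step size at all for this change, and any expectation in this assay rests on the structural change alone.

For compound 4 the estimated value is 6 ug/mL, with a range from 1 ug/mL to 40 ug/mL. The step this estimate implies, an at least 2.0-fold higher number from compound 2 to compound 4 (0.30 log units; that floor lies within the scatter), is an expectation only, with a real chance that the assay again reports a limit.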

Compound 4, solubility: < 3 ug/mL
Compound 4 ended at the assay's limit; the forecaster's own chance of this, stated with the estimate: 45%; at least 2.0-fold (0.30 log units) between middle value and limit.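

Compound 4 also gives only a limit in this assay, so no new step can be read between it and compound 1, compound 2 or compound 3: the limit of < 3 ug/mL in this assay, at which 4 of the 4 values shown sit. The compounds shown leave open what the actual solubility of each of the four is, and so whether amino in place of 2-hydroxyethyl changes the read-out at all.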